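The source may report more compounds than this note shows. Statements on the series, on what has been measured and on what is new or still open speak of the compounds shown alone.

Measured so far in a functional assay on MCF7 cells (Homo sapiens) for inhibition, read by sulforhodamine B assay, with a stated time of 72 h; a lower number here means a stronger inhibitor of growth, a higher number a weaker inhibitor of growth
- compound 1 `CCOC(=O)/C=C/c1ccncc1-c1ccc2ccccc2c1` gives 8320 nM
- compound 2 `CNC(=O)CCc1ccncc1-c1ccc2ccccc2c1` gives > 10000 nM as a limit
- compound 3 `COC1CN(C(=O)/C=C/c2ccncc2-c2ccc3ccccc3c2)C1` gives > 10000 nM as a limit

Compound 3 stands at the limit of > 10000 nM in this assay, at which 2 of the 3 values shown sit, and carries only a limit, not a number. Compound 4 `CN(C)C(=O)/C=C/c1ccncc1-c1ccc2ccccc2c1` differs from it by dimethylamino in place of 3-methoxyazetidin-1-yl on a carbonyl carbon and the same change reads (3-methoxyazetidin-1-yl)carbonyl to dimethylcarbamoyl. For the measured compounds named here, two measured steps bear on it. The step of an at least 1.2-fold higher number from compound 1 to compound 3 (0.07 log units; that floor lies within the scatter) on a carbonyl carbon is only a floor within the scatter, and the step of an at least 1.2-fold higher number from compound 1 to compound 2 (0.07 log units; that floor lies within the scatter) is the same. No step beyond the scatter is therefore expected in this assay, in either direction, and another limit is likely. The expected step is a number no higher from compound 3 to compound 4 (the limit leaves the size open) and it stays within the scatter. Compound 4 is estimated at 10000 nM with an expected range from 5000 nM to 20000 nM in this read-out.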

Compound 4, concentration for 50% growth inhibition: 8190 nM
The estimate for compound 4 lay 1.2-fold (0.09 log units) above the measured number; the range from low to high includes it.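

In this assay, dimethylamino in place of ethoxy on a carbonyl carbon gives a 1.0-fold lower number from compound 1 to compound 4 (0.01 log units; within the scatter), so this exchange brings no step beyond the scatter. Compound 4 shows that an amide at this place can give a number rather than a limit, yet an at least 1.2-fold lower number from compound 3 to compound 4 (0.08 log units; that floor lies within the scatter) and an at least 1.2-fold lower number from compound 2 to compound 4 (0.08 log units; that floor lies within the scatter) are floors only, and both rest on limits: the limit of > 10000 nM in this assay, at which 2 of the 4 values shown sit.

As far as these compounds go, whether any group on this carbonyl carbon can move the number beyond the scatter stays open. A carboxylic acid, or a longer chain carrying an amine, at this place would test that.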